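From methoxy to methyl on the way to compound 4

The source may hold more compounds than are shown below. What is called first, only, known or untested is meant among the compounds shown, and "the series" means these compounds.

Measured so far in a functional assay on HeLa cells (Homo sapiens) for antiproliferative activity, read by MTT assay, with a stated time of 48 h; a lower number here means a stronger inhibitor, a higher number a weaker inhibitor:
- Compound 1 `Cc1ccc2nc(NC(c3cn(-c4ccccc4)nc3-c3cccc([N+](=O)[O-])c3)c3c(O)ccc4ccccc34)sc2c1`: 7360 nM
- Compound 2 `O=[N+]([O-])c1ccc(-c2nn(-c3ccccc3)cc2C(Nc2nc3ccccc3s2)c2c(O)ccc3ccccc23)cc1`: 6810 nM
- Compound 3 `COc1ccc2nc(NC(c3cn(-c4ccccc4)nc3-c3ccc([N+](=O)[O-])cc3)c3c(O)ccc4ccccc34)sc2c1`: 5540 nM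

The three values lie within the scatter of one another, so compound 3, at 5540 nM, cannot be separated from compound 1 or compound 2 in this assay. Compound 4 `Cc1ccc2nc(NC(c3cn(-c4ccccc4)nc3-c3ccc([N+](=O)[O-])cc3)c3c(O)ccc4ccccc34)sc2c1` has not yet been measured. Its difference from compound 3 is methyl in place of methoxy on an aromatic carbon, which in words is methyl in place of methoxy on an aromatic carbon.

For the measured compounds named here, one measured step bears directly on this change, the placing of methoxy in place of hydrogen on an aromatic carbon: a 1.2-fold lower number from compound 2 to compound 3 (0.09 log units; within the scatter). Compound 1 also carries a methyl group and gives 7360 nM, in line with the other two values. No step beyond the scatter is therefore expected. The estimated step is a 1.1-fold higher number from compound 3 to compound 4 (0.03 log units; within the scatter). For compound 4 the expected value is 6000 nM, with an estimated range of 3300 nM to 10500 nM.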

Compound 4, half-maximal inhibitory concentration: 7040 nM
Beside the measured number, compound 4's estimate is 1.2-fold (0.07 log units) below it; measured number inside the range.
By their numbers in this assay, from the lowest: compounds 3, 2, 4 and 1 (each within the scatter of the next).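

In this assay, the 6-methyl-1,3-benzothiazol-2-yl and 6-methoxy-1,3-benzothiazol-2-yl groups cannot be separated (a 1.3-fold higher number from compound 3 to compound 4 (0.10 log units; within the scatter)), so methyl in place of methoxy on this aromatic carbon gives no readable difference. Methyl in place of hydrogen on the same carbon also stays within the scatter (a 1.0-fold higher number from compound 2 to compound 4 (0.01 log units; within the scatter)), and so hydrogen, methyl and methoxy can no longer be told apart here in the compounds shown. With the methyl group held constant, 4-nitrophenyl in place of 3-nitrophenyl is likewise within the scatter (a 1.0-fold lower number from compound 1 to compound 4 (0.02 log units; within the scatter)), which extends the same result to a second place on the molecule. Nothing available explains these results. The compounds shown leave open whether an amine or a carboxylic acid on this aromatic carbon would give a step beyond the scatter. They also leave open whether replacing the nitro group with a nitrile would do so.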